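Ring-substitution swap on a benzoxazole sulfonamide series

The source may report more compounds than this note shows. Statements on the series, on what has been measured and on what is new or still open speak of the compounds shown alone.

Three aryl sulfonamides sharing one core have been examined in an ADME assay on HEK293 cells (Homo sapiens) for cytotoxicity, read by resazurin assay, with a stated time of 48 h; a lower number here means that less compound is tolerated, a higher number that more compound is tolerated. Compound 1 `O=S(=O)(Nc1ccc2oc(-c3ccccc3)nc2c1)c1ccc(Cl)c(Cl)c1` gives 71000 nM, compound 2 `O=S(=O)(Nc1ccc2oc(-c3ccccc3)nc2c1)c1ccccc1F` gives 72000 nM, and compound 3 `O=S(=O)(Nc1ccc2oc(-c3ccccc3)nc2c1)c1ccc(Cl)cc1` gives 65000 nM. The three numbers sit together inside one band of scatter: a 1.0-fold higher number from compound 1 to compound 2 (0.01 log units; within the scatter), a 1.1-fold lower number from compound 1 to compound 3 (0.04 log units; within the scatter) and a 1.1-fold lower number from compound 2 to compound 3 (0.04 log units; within the scatter) are all too small to separate any one of them. Compound 3 therefore stands level with compound 1 and compound 2 rather than apart from them.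

Compound 4 `O=S(=O)(Nc1ccc2oc(-c3ccccc3)nc2c1)c1cccc(Cl)c1` differs from compound 3 by 3-chlorophenyl in place of 4-chlorophenyl on a sulfonyl sulfur. Going by the values given here, the steps that bear on this change are those that already altered the aryl group on the sulfonyl sulfur, namely a 1.1-fold lower number from compound 1 to compound 3 (0.04 log units; within the scatter) and a 1.1-fold lower number from compound 2 to compound 3 (0.04 log units; within the scatter), and neither reached beyond the scatter. On that basis the writer expects no step beyond the scatter for no change at the digits printed from compound 3 to compound 4 (within the scatter) in this assay. Compound 4 is estimated at 65000 nM, with a range from 40000 nM to 110000 nM.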

Compound 4, half-maximal cytotoxic concentration: 70000 nM
Compound 4: middle estimate off by 1.1-fold (0.03 log units), on the low side, within the range that was stated.
By their numbers in this assay, from the lowest: compounds 3, 4, 1 and 2 (each within the scatter of the next).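

Set in this assay, the swap of 4-chlorophenyl for 3-chlorophenyl on the sulfonyl sulfur gives a 1.1-fold higher number from compound 3 to compound 4 (0.03 log units; within the scatter). Going by these compounds alone, the two compounds have the same atoms joined differently, and this step isolates where the chloro group sits on that aryl ring, which no earlier pair did. The other two new steps, a 1.0-fold lower number from compound 2 to compound 4 (0.01 log units; within the scatter) and a 1.0-fold lower number from compound 1 to compound 4 (0.01 log units; within the scatter), place 3-chlorophenyl level with 2-fluorophenyl and 3,4-dichlorophenyl, so all four aryl groups shown stay within the scatter of one another. Nothing available explains why these numbers stay together.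

Every aryl group shown carries only chloro or fluoro, so whether an amine or a carboxylic acid on that ring would shift the number remains open. All four compounds also keep the shared core unchanged, which leaves the effect of any change there unknown.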